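One Inverted Stereocentre, Permeability Still Unknown

The compounds below may be only part of what the source reports. "The series", "measured", "known", "first", "only" and "open" are said of these compounds alone.

In an ADME assay on MDCK cells (Canis lupus familiaris) for permeability, read by LC-MS, with a stated time of 90 min, tested at 2 uM (on this read-out higher numbers stand for higher permeability and lower numbers for lower permeability), compound 1 `Cc1cc(C)c(CN2CCc3c(Cl)cc(-c4c(C)noc4C)c(Cl)c3C2=O)c(=O)[nH]1` gives 15.7 10^-6 cm/s. Compound 2 `Cc1cc(C)c(CN2CCc3c(Cl)cc([C@H](C)CO)c(Cl)c3C2=O)c(=O)[nH]1` gives 12.4 10^-6 cm/s, which stands within the usual scatter of the value for compound 1. Compound 3 `Cc1cc(C)c(CN2CCc3c(Cl)cc([C@@H](C)CO)c(Cl)c3C2=O)c(=O)[nH]1` is the mirror-image counterpart at one centre: the two compounds have the same atoms and bonds and differ only in configuration as drawn: 1 of 1 stereo elements differ; a stereocentre at a saturated chain carbon is drawn S in compound 2 and R in compound 3. A stereocentre at a saturated chain carbon is drawn S in compound 2 and R in compound 3. Among the compounds with values here, no measured step isolates a change of configuration, so the evidence is only indirect. Within the data shown here, the single measured step exchanges a whole group and still stays within the scatter: a 1.3-fold lower number from compound 1 to compound 2 (0.10 log units; within the scatter). On these data alone, on that basis, no shift beyond the scatter is expected in this assay for this smaller change, and the direction remains open. The expected step is a 1.0-fold higher number from compound 2 to compound 3 (0.00 log units; within the scatter). For compound 3 the estimated value is 12.5 10^-6 cm/s, with an expected range from 7 10^-6 cm/s to 21 10^-6 cm/s.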

Compound 3, apparent permeability: 15 10^-6 cm/s
Compound 3: the middle estimate sits 1.2-fold (0.08 log units) below what was measured; the measured number falls inside the stated range.
By their numbers in this assay, from the lowest: compounds 2, 3 and 1 (each within the scatter of the next).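

Within the data shown here, the new result gives the first direct reading on configuration at this saturated chain carbon: in this assay, the change from S to R gives a 1.2-fold higher number from compound 2 to compound 3 (0.08 log units; within the scatter). The reading isolates that one feature: the fact that compounds 2 and 3 differ only in the configuration as drawn. Compound 3 also stands close to the 3,5-dimethyl-1,2-oxazol-4-yl compound, with a 1.0-fold lower number from compound 1 to compound 3 (0.02 log units; within the scatter), so both drawn configurations of 1-(hydroxymethyl)ethyl lie within the scatter of that group on this aromatic carbon.

The compounds shown leave open whether configuration at this centre would still make so little difference in this assay if a carboxylic acid or an amine stood in place of the hydroxyl group, or if a longer chain carried it. They also leave open whether the two configurations read alike in any other assay.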